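This account rests on a few compounds, and the source may have more. Where it says the series, first, only, none or still open, it means among the compounds named here.

Compounds measured so far:

compound 1 `COc1ccccc1N1C(=O)CSC1C(=O)NCCCCc1ccccc1` — 0%
compound 2 `COc1ccc(F)cc1N1C(=O)CSC1c1cccc(C(=O)NCCCCc2ccccc2)c1` — 46%
compound 3 `CCN1C(=O)CSC1c1cccc(C(=O)NCCCCc2ccccc2)c1` — 6%

All three were tested in a functional assay on HOS cells (Homo sapiens) for inhibition, read by CCK-8 assay, with a stated time of 72 h, tested at 1 uM; on this read-out lower numbers stand for less inhibition and higher numbers for more inhibition at the one concentration tested (going by the name of the read-out). Among them, compound 2 stands highest: compound 3 sits nearest to it, and compound 1 lies furthest away. Among the compounds with values here, the one single-point step among the measured compounds runs from compound 2 to compound 3, where ethyl replaces 5-fluoro-2-methoxyphenyl on an amide-type nitrogen in a ring, and it gives a number 40 percentage points lower from compound 2 to compound 3 (beyond the scatter). Within the data shown here, compound 1 carries the aryl amide directly on the five-membered ring rather than on an intervening benzene, so no single step connects it to the others; its value and that of compound 2 simply show a large gap.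

Compound 4 `COc1cc(F)ccc1N1C(=O)CSC1c1cccc(C(=O)NCCCCc2ccccc2)c1` keeps the same atoms as compound 2 but joins them differently: 4-fluoro-2-methoxyphenyl in place of 5-fluoro-2-methoxyphenyl on an amide-type nitrogen in a ring. Among the measured compounds shown here, nothing among the measured compounds shows what moving a fluorine around the ring does; the only step known concerns the whole aryl group being lost in favour of ethyl, which is a much larger change than the one at hand. With the aryl group retained and only the fluorine shifted, the author expects no step beyond the scatter, so compound 4 is estimated at 42%, within a range of 18% to 64%, which would mean an expected step of a number 4 percentage points lower from compound 2 to compound 4 (within the scatter).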

Compound 4, a percentage reported as inhibition, at one concentration (the size of the read-out at that concentration, not a potency): 81%
Compound 4: middle estimate off by 39 percentage points, on the low side; measured number outside the range, above it.
By their numbers in this assay, from the lowest: compounds 1 and 3 (each within the scatter of the next); then compound 2; then compound 4.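

The ring nitrogen position responds not only to whether an aryl group is present but also to where the fluorine sits on that aryl group: in this assay, exchanging 5-fluoro-2-methoxyphenyl for 4-fluoro-2-methoxyphenyl gives a number 35 percentage points higher from compound 2 to compound 4 (beyond the scatter). The two groups match in everything counted, from heavy atoms and ring type to hydrogen-bond donors, acceptors and charge, so those counts cannot separate them, and the arrangement of the same atoms is enough to produce a large step. The loss seen on going to ethyl, a number 40 percentage points lower from compound 2 to compound 3 (beyond the scatter), therefore gave only part of the picture, since the aryl group with the fluorine in its new place gives a number 75 percentage points higher from compound 3 to compound 4 (beyond the scatter).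

Nothing given here explains why moving the fluorine changes the number so strongly. The compounds shown leave open whether 4-chloro-2-methoxyphenyl or 2-ethoxy-4-fluorophenyl on that nitrogen would keep the number as high as in compound 4, and a reading at one concentration does not give the potency of any of these compounds.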